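The compounds below may be only part of what the source reports. "The series", "measured", "known", "first", "only" and "open" are said of these compounds alone.

Compound 1 `COc1ccc(Nc2cc(C)nc(SCc3nc4ccccc4[nH]3)n2)cc1` gives 67400 nM in a functional assay on PC-3 cells (Homo sapiens) for cytotoxicity, read by MTT assay, with a stated time of 72 h; on this read-out lower numbers stand for stronger inhibition and higher numbers for weaker inhibition.
Compound 2 `Cc1cc(N2CCNCC2)nc(SCc2nc3ccccc3[nH]2)n1` reaches only the limit of this assay, > 100000 nM.
Compound 3 `Cc1cc(NC(C)C)nc(SCc2nc3ccccc3[nH]2)n1` likewise stands at a limit of this assay, > 100000 nM.

Of the three measured compounds, only compound 1 yields a number in this assay; the other two sit at the limit of > 100000 nM in this assay, at which 2 of the 3 values shown sit, so compound 3 is known only as weaker than the top of the measurable range, and how far weaker is not known. The step of an at least 1.4-fold higher number from compound 1 to compound 2 (0.17 log units; that floor lies within the scatter) and the step of an at least 1.4-fold higher number from compound 1 to compound 3 (0.17 log units; that floor lies within the scatter) are both floors that fall within the ordinary scatter, and the step that the two limits leave unreadable from compound 2 to compound 3 cannot be read at all, since both of its ends are limits.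

The unmeasured compound 4 `Cc1cc(N(C)Cc2ccccc2)nc(SCc2nc3ccccc3[nH]2)n1` differs from compound 3 in one place: benzyl(methyl)amino in place of isopropylamino on an aromatic carbon. For the measured compounds named here, the nearest measured step is the one from compound 1 to compound 3, where the loss of the 4-methoxyphenyl group on the ring nitrogen took the value from a number to a limit; compound 4 brings an aromatic ring back to that amine, though without a hydrogen-bond donor. He therefore expects compound 4 to move back toward the value of compound 1, a step of about an at least 1.4-fold lower number from compound 3 to compound 4 (0.15 log units; that floor lies within the scatter), with a real chance that it again stays at a limit. His estimate for compound 4 in this assay is 70000 nM, within the range 25000 nM to 200000 nM.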

Compound 4, half-maximal inhibitory concentration: > 100000 nM
Compound 4 was reported as a limit (the forecaster's own chance of this, stated with the estimate: 45%); middle value at least 1.4-fold (0.15 log units) from the limit.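

Adding an aromatic ring to the amine at this position does not by itself restore a number in this assay, since benzyl(methyl)amino, like isopropylamino and piperazin-1-yl, gives only a limit, and compound 1 alone still has a numerical value: the limit of > 100000 nM in this assay, at which 3 of the 4 values shown sit.
For the compounds shown here, the one readable new step is an at least 1.4-fold higher number from compound 1 to compound 4 (0.17 log units; that floor lies within the scatter), so the data do not establish a real difference between these two compounds. The steps among compound 2, compound 3 and compound 4 cannot be read, as both ends of each are limits, and these three compounds therefore cannot be ranked.

Compound 4 differs from compound 1 in several features at once: it lacks the amine hydrogen and the methoxy group, and it has a methyl on the nitrogen and a carbon link to the ring, so the compounds shown do not reveal which of these features matters. On these data alone, a benzylamino group, which retains the amine hydrogen, or an unsubstituted phenylamino group at this position could help separate these features, and how either would read in this assay remains open.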